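The source may report more compounds than this note shows. Statements on the series, on what has been measured and on what is new or still open speak of the compounds shown alone.

Three measured compounds share one core and differ only in the group carried on the benzyl phenyl. Compound 1 `N#Cc1ccc(Cn2cc(/C=C3\NC(=O)NC3=O)c3ccccc32)cc1`, compound 2 `O=C1NC(=O)/C(=C/c2cn(Cc3ccc([N+](=O)[O-])cc3)c3ccccc23)N1` and compound 3 `COC(=O)c1ccc(Cn2cc(/C=C3\NC(=O)NC3=O)c3ccccc32)cc1` were each tested in a functional assay on MCF7 cells (Homo sapiens) for antiproliferative activity, read by trypan blue exclusion, with a stated time of 24 h; a lower number here means a stronger inhibitor, a higher number a weaker inhibitor. In this assay compound 1 gives 14100 nM, compound 2 gives 10900 nM and compound 3 gives 15400 nM. Compound 2 has the lowest number of the three, though every step among them is small: a 1.3-fold lower number from compound 1 to compound 2 (0.11 log units; within the scatter), a 1.4-fold higher number from compound 2 to compound 3 (0.15 log units; within the scatter) and, closing the triangle, a 1.1-fold higher number from compound 1 to compound 3 (0.04 log units; within the scatter), so none of the three is set apart.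

Compound 4 `O=C1NC(=O)/C(=C/c2cn(Cc3ccccc3Br)c3ccccc23)N1` is not yet measured. The change from compound 2 is 2-bromophenyl in place of 4-nitrophenyl on a saturated chain carbon bound to an aromatic nitrogen. The three measured steps all swap one group for another on the same phenyl ring and all stay within the scatter; none of them moves a group to a new place on that ring or brings in bromine, so they bear only loosely on this step. Given that, compound 4 is expected to sit near its neighbours, with the step estimated at a 1.1-fold higher number from compound 2 to compound 4 (0.04 log units; within the scatter). Compound 4 is therefore estimated at 12000 nM, within a range from 5000 nM to 30000 nM.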

Compound 4, half-maximal inhibitory concentration: 4400 nM
The estimate for compound 4 lay 2.7-fold (0.44 log units) above the measured number, and the stated range ends above it.
By their numbers in this assay, from the lowest: compound 4; then compounds 2, 1 and 3 (each within the scatter of the next).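

In this assay, going by these compounds alone, the change to 2-bromophenyl gives a 2.5-fold lower number from compound 2 to compound 4 (0.39 log units; beyond the scatter) and a 3.2-fold lower number from compound 1 to compound 4 (0.51 log units; beyond the scatter), the only steps in this set that lie beyond the scatter. Within the data shown here, the swaps among the earlier groups on the benzyl phenyl had all stayed within the scatter, so compound 4 is the first sign that the number at this position can respond to the group carried on the saturated chain carbon bound to an aromatic nitrogen. Nothing measured here bears on why the number moved.

The identity of the group and its place on the ring change together in this step, so the compounds shown do not separate the two. On these data alone, whether chlorine, a methoxy group or an amine on that phenyl would give a similar number also remains open.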